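This account rests on a few compounds, and the source may have more. Where it says the series, first, only, none or still open, it means among the compounds named here.

Compound 1 `O=C(Nc1cccc(F)c1)c1cc(=O)[nH]c2cc(-c3ccc(F)cc3)ccc12`: 3300 nM
Compound 2 `COc1ccc(-c2ccc3c(C(=O)Nc4cccc(F)c4)cc(=O)[nH]c3c2)cc1`: > 20000 nM

In a functional assay on KYSE-70 cells for antiproliferative activity against KYSE-70 cell line (Homo sapiens), read by MTT assay, with a stated time of 72 h (a higher number here means a weaker inhibitor, a lower number a stronger inhibitor), compound 1 gives 3300 nM. Compound 2 stands at > 20000 nM, which is a limit of the assay and not a number.

Within the data shown here, only one measured step bears on the next change: an at least 6.0-fold higher number from compound 1 to compound 2 (0.78 log units; beyond the scatter), with methoxy in place of fluoro on an aromatic carbon. That step ends on (the limit of > 20000 nM in this assay, at which 1 of the 2 values shown sits), so its size is a bound and not a measured gap.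

Compound 3 `O=C(Nc1cccc(F)c1)c1cc(=O)[nH]c2cc(-c3ccccc3F)ccc12` is reached from compound 2 by 2-fluorophenyl in place of 4-methoxyphenyl on an aromatic carbon, para to a fused ring. Among the measured compounds shown here, the methoxy leaves and a fluoro enters, so the change runs against the direction of the one measured step. A move to a lower number in this assay is therefore expected, resting on compound 1 at 3300 nM and on an at least 6.0-fold higher number from compound 1 to compound 2 (0.78 log units; beyond the scatter). With a single step behind it, this expectation remains loose, and a further limit reading cannot be ruled out.

The expected change is an at least 3.3-fold lower number from compound 2 to compound 3 (0.52 log units; beyond the scatter).

For compound 3 the estimated value is 6000 nM, with an expected range of 2000 nM to 20000 nM.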

Compound 3, half-maximal inhibitory concentration: > 20000 nM
Compound 3: only a limit was reported; the forecaster's own chance of this, stated with the estimate: 25%; middle value at least 3.3-fold (0.52 log units) from the limit.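

In this assay, 2-fluorophenyl in place of 4-fluorophenyl on the same aromatic carbon of the shared core gives an at least 6.0-fold higher number from compound 1 to compound 3 (0.78 log units; beyond the scatter), so a fluorophenyl at this position does not by itself preserve a measurable reading. The earlier pair changed methoxy for fluoro with the phenyl attachment unchanged, whereas this pair keeps the fluoro and changes only its place on the phenyl, and of the three groups shown only 4-fluorophenyl gives a number rather than a limit. Compound 3 reads only as a limit of the assay, so the step from compound 2 cannot be read and the 2-fluorophenyl and 4-methoxyphenyl groups cannot be ranked against each other: the limit of > 20000 nM in this assay, at which 2 of the 3 values shown sit.

Still open, as far as these compounds go, is how an unsubstituted phenyl, or a phenyl carrying an amine or a carboxylic acid, would read at this position in this assay. Also open, from the compounds shown here alone, is whether any group here can give a lower number than compound 1 at 3300 nM, and whether the sensitivity to the place of the fluoro persists when the rest of the shared core changes.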